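Estimating Lipophilicity After a Fluoro-for-Hydrogen Swap

This account rests on a few compounds, and the source may have more. Where it says the series, first, only, none or still open, it means among the compounds named here.

Measured compounds:
Compound 1, `COc1c(OC)c(OC(C)=O)c2ccccc2c1OC(C)=O`: 2.39
Compound 2, `COc1c(OC)c(OC(C)=O)c2c(Cl)cccc2c1OC(C)=O`: 3.16

In a physicochemical assay for lipophilicity (on this read-out higher numbers stand for higher lipophilicity and lower numbers for lower lipophilicity), compound 1 gives 2.39, the lower of the two numbers. Its nearest neighbour is compound 2, which in this assay gives 3.16. Among the compounds with values here, the one step between these two, a number 0.77 log units higher from compound 1 to compound 2 (beyond the scatter), comes from a single change on the shared core of compound 1.

Compound 3, `COc1c(OC)c(OC(C)=O)c2cc(F)ccc2c1OC(C)=O`, has not yet been measured. It differs from compound 1 as follows: fluoro in place of hydrogen on an aromatic carbon. Within the data shown here, the chloro step a number 0.77 log units higher from compound 1 to compound 2 (beyond the scatter) is the only measured comparison that bears on this, and it involves a different halogen on the same kind of position. Fluorine is the smaller atom, so a shift in the same direction but of smaller size is expected, possibly close to the scatter.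

For compound 3 the expected step is a number 0.16 log units higher from compound 1 to compound 3 (within the scatter). The estimated value for compound 3 in this assay is 2.55, with a likely range from 2.25 to 2.85.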

Compound 3, partition coefficient: 2.75
The estimate for compound 3 lay 0.20 log units below the measured number; the measured number falls inside the stated range.
By their numbers in this assay, from the lowest: compound 1; then compound 3; then compound 2.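

In this assay, fluoro in place of hydrogen on this aromatic carbon, meta to a fused ring and para to a fused ring, gives a number 0.36 log units higher from compound 1 to compound 3 (beyond the scatter) and so even a swap of a single heavy atom for hydrogen can be read on this scale. Until now only a chloro step was known on the shared core, and this result shows that a second halogen, on this carbon, also moves the number upward, so that compound 2 and compound 3 both stand above compound 1. Nothing available here says why the number moves at this position.

Compound 2 and compound 3 differ in more than one place, so the two steps cannot tell whether the size of a shift follows the halogen or the carbon that carries it, and settling that would take chloro and fluoro on the same carbon. Also open is how a group of another kind, such as an amine or a carboxylic acid, would behave at this carbon of the core, where only hydrogen and fluoro are shown.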